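The source may report more compounds than this note shows. Statements on the series, on what has been measured and on what is new or still open speak of the compounds shown alone.

Measured compounds in a functional assay on A549 cells (Homo sapiens) for inhibition, read by MTT assay, with a stated time of 72 h; a higher number here means a weaker inhibitor, a lower number a stronger inhibitor:
compound 1 `O=C(Nc1ccc(Oc2ccnc3[nH]ccc23)cc1)c1cn(-c2ccc(F)cc2)c2ccccc2c1=O` gives 390 nM
compound 2 `O=C(Nc1ccc(Oc2ccnc3[nH]ccc23)cc1)c1cn(-c2ccc(Br)cc2)c2ccccc2c1=O` gives 450 nM

Among the measured compounds shown here, compound 2 holds the highest of the two numbers so far, but the one step recorded between them, a 1.2-fold higher number from compound 1 to compound 2 (0.06 log units; within the scatter), lies within the scatter, so the two values are read as the same and no order between compound 1 and compound 2 is drawn.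

Compound 3 `O=C(Nc1ccc(Oc2ccnc3[nH]ccc23)cc1)c1cn(-c2ccc(Br)cc2F)c2ccccc2c1=O` has not been measured in this assay. It differs from compound 2 by fluoro in place of hydrogen on an aromatic carbon. For the measured compounds named here, the only measured step, from compound 1 to compound 2, concerns a different change on the same ring, the exchange of one halogen for another, and it left the number essentially where it was. Going by the values given here, nothing measured so far tests an added fluoro on this ring, so the expectation rests on the observation that the one change made to this ring did not move the number beyond the scatter.

For compound 3 a step of no change at the digits printed from compound 2 to compound 3 (within the scatter) is therefore expected, that is, no change beyond the scatter, with the value estimated at 450 nM and a range from 180 nM to 1100 nM.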

Compound 3, half-maximal inhibitory concentration: 1330 nM
Estimate against measurement, compound 3: 3.0-fold (0.47 log units) below; the measured number lies above the stated range.
By their numbers in this assay, from the lowest: compounds 1 and 2 (each within the scatter of the next); then compound 3.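

In this assay, the 4-bromophenyl group proves sensitive to an added substituent: fluoro on the aromatic carbon ortho to a large group and meta to the bromo group gives a 3.0-fold higher number from compound 2 to compound 3 (0.47 log units; beyond the scatter), a modest step beyond the scatter, whereas the halogen exchange, a 1.2-fold higher number from compound 1 to compound 2 (0.06 log units; within the scatter), stayed within it. Among the compounds shown here, the step to the 4-bromo-2-fluorophenyl group from the 4-fluorophenyl group, a 3.4-fold higher number from compound 1 to compound 3 (0.53 log units; beyond the scatter), is of modest size too, so compound 3 stands apart from both compound 1 and compound 2, and this position is the first place on the ring where a change moves the number beyond the scatter. No evidence at hand bears on why the number rises with this change.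

The compounds shown carry only fluoro at this position, so it remains open whether the rise belongs to fluoro itself or would also appear with a chloro, methyl or methoxy group on the same carbon. Also open, on these data alone, is whether the same fluoro would raise the number on the 4-fluorophenyl group of compound 1, and how an amine or a carboxylic acid would read in place of the bromo group.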